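Working notes: from compound 2 to compound 4

This account rests on a few compounds, and the source may have more. Where it says the series, first, only, none or still open, it means among the compounds named here.

In a functional assay on SK-BR-3 cells (Homo sapiens) for antiproliferative activity, read by MTT assay, with a stated time of 72 h (on this read-out lower numbers stand for stronger inhibition and higher numbers for weaker inhibition), compound 2 `Cc1cc(N2CCCC2)nc2ccc(NC(=O)c3ccc(Cl)c(Cl)c3)cc12` gives 43400 nM. Compound 1 `CCN1CCN(c2cc(C)c3cc(NC(=O)c4ccccc4C)ccc3n2)CC1` gives 29200 nM and compound 3 `CCc1ccccc1C(=O)Nc1ccc2nc(N3CCN(CC)CC3)cc(C)c2c1` gives 23900 nM. Both lie within the scatter of compound 2, so the three values form a single level.

Compound 4 `Cc1cc(NCCN2CCCC2)nc2ccc(NC(=O)c3ccc(Cl)c(Cl)c3)cc12` keeps the rest of compound 2 and changes one group on an aromatic carbon next to the ring nitrogen, where (2-(pyrrolidin-1-yl)ethyl)amino stands in place of pyrrolidin-1-yl: (2-(pyrrolidin-1-yl)ethyl)amino in place of pyrrolidin-1-yl on an aromatic carbon.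

Among the measured compounds shown here, the only measured step, a 1.2-fold lower number from compound 1 to compound 3 (0.09 log units; within the scatter), stays within the scatter. It is a methyl in place of hydrogen on a saturated chain carbon bound to an aromatic carbon, so it does not test this exchange. For the measured compounds named here, no measured pair changes only the group on the carbon in question, and the expectation is therefore a loose judgement. The expected outcome in this assay is a moderate move toward a lower number, a 2.7-fold lower number from compound 2 to compound 4 (0.43 log units; beyond the scatter). For compound 4 the estimate is 16000 nM, with an expected range of 4000 nM to 45000 nM.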

Compound 4, half-maximal inhibitory concentration: 9530 nM
Compound 4: middle estimate off by 1.7-fold (0.23 log units), on the high side, within the range that was stated.
By their numbers in this assay, from the lowest: compound 4; then compounds 3, 1 and 2 (each within the scatter of the next).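

In this assay, among the compounds shown here, (2-(pyrrolidin-1-yl)ethyl)amino in place of pyrrolidin-1-yl on the aromatic carbon next to the ring nitrogen gives a 4.6-fold lower number from compound 2 to compound 4 (0.66 log units; beyond the scatter) and is the only step so far beyond the scatter, so the number does respond to the group at this position. The pyrrolidine ring is present on both sides of the step, while the entering group brings more heavy atoms, a hydrogen-bond donor and a further hydrogen-bond acceptor, and this single step cannot separate these differences. No available evidence bears on why the number moves.

As far as these compounds go, whether a propyl chain in place of the ethyl chain, or a dimethylamino group in place of the terminal pyrrolidine, would carry the number further stays open. Also open, from the compounds shown here alone, is whether the same exchange has a similar effect when the dichlorobenzamide part is replaced by another amide.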